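A few compounds are considered here, and "the series" means these few. Any claim that something is new, unique, unknown or untested is made for them only; others in the source may bear on it.

In a functional assay on MDA-MB-231 cells (Homo sapiens) for cytotoxicity, read by MTT assay, with a stated time of 72 h (on this read-out lower numbers stand for stronger inhibition and higher numbers for weaker inhibition), compound 1 `O=C1c2c[n+]([O-])c3ccccc3c2C(=O)c2c1c1ccccc1n2Cc1cn(C[C@H](O)CO)nn1` gives 1310 nM, compound 2 `O=C1c2c[n+]([O-])c3ccccc3c2C(=O)c2c1c1ccccc1n2CCN1CCCC1` gives 630 nM, and compound 3 `CCCCN1CCN(CCCCn2c3c(c4ccccc42)C(=O)c2c[n+]([O-])c4ccccc4c2C3=O)CC1` gives 900 nM. Compound 3 therefore lies within the scatter of both other compounds, while those two lie just beyond the scatter of each other.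

Compound 4 `CN1CCN(CCCCCn2c3c(c4ccccc42)C(=O)c2c[n+]([O-])c4ccccc4c2C3=O)CC1` departs from compound 3 in one place: (4-methylpiperazin-1-yl)methyl in place of 4-butylpiperazin-1-yl on a saturated chain carbon, four bonds along the chain from an aromatic nitrogen. It carries (4-methylpiperazin-1-yl)methyl in place of 4-butylpiperazin-1-yl, on a saturated chain carbon, four bonds along the chain from an aromatic nitrogen.

Among the compounds with values here, no measured step shows this exact exchange, but two bear on it. The first is a 2.1-fold lower number from compound 1 to compound 2 (0.32 log units; beyond the scatter). The second is a 1.4-fold higher number from compound 2 to compound 3 (0.15 log units; within the scatter), and it is the closer guide, since it introduces the 4-butylpiperazin-1-yl group that compound 4 gives up. Both steps replaced larger parts of the side chain than this change does, and neither was large, so no step beyond the scatter is expected.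

The estimated step is a 1.1-fold lower number from compound 3 to compound 4 (0.05 log units; within the scatter). Compound 4 is expected at 800 nM, with an estimated range of 350 nM to 1800 nM.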

Compound 4, half-maximal inhibitory concentration: 2270 nM
For compound 4 the middle estimate is 2.8-fold (0.45 log units) below the measured one, and the stated range ends below it.
By their numbers in this assay, from the lowest: compounds 2, 3, 1 and 4 (each within the scatter of the next, the first and the last beyond it).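

In this assay, the exchange at this position is the first among the compounds shown to pair a change at the end of the side chain with a step beyond the scatter: a 2.5-fold higher number from compound 3 to compound 4 (0.40 log units; beyond the scatter), although the step from compound 2 to compound 3 had stayed within it. The wider comparisons place compound 4 clearly apart from the pyrrolidine compound, with a 3.6-fold higher number from compound 2 to compound 4 (0.56 log units; beyond the scatter), the largest step shown, whereas a 1.7-fold higher number from compound 1 to compound 4 (0.24 log units; within the scatter) remains within the scatter. Nothing available here accounts for the step.

Because the exchange shortens the group on the piperazine and lengthens the chain to the ring, the compounds shown do not separate these two changes. On these data alone, it also remains open how a morpholine or an unsubstituted piperazine at the end of this chain would read.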